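This account rests on a few compounds, and the source may have more. Where it says the series, first, only, none or still open, it means among the compounds named here.

Working notes on the series in a functional assay on CHO cells for antagonist activity at metabotropic glutamate receptor 5 (Homo sapiens), read by calcium flux; on this read-out lower numbers stand for stronger inhibition and higher numbers for weaker inhibition. Among the measured compounds shown here, compound 3 `Cc1c(C(C)OC(=O)Nc2ccccc2)oc2nc(Cl)nn12` gives 10 nM, the lowest of the three numbers so far. Compound 2 `Cc1c(C(C)OC(=O)Nc2cccc(Cl)c2)oc2ncnn12` gives 39.8 nM, and compound 1 `Cc1c(C(C)OC(=O)NC2CCCCC2)oc2ncnn12` gives 3160 nM. For the measured compounds named here, the only single-point step measured, a 79-fold lower number from compound 1 to compound 2 (1.90 log units; beyond the scatter), concerns the group on the carbamate nitrogen and does not touch the core.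

Compound 4 `Cc1nc2oc(C(C)OC(=O)Nc3ccccc3)c(C)n2n1` differs from compound 3 by methyl in place of chloro on an aromatic carbon. Going by the values given here, no measured pair isolates a change at this position of the core; compound 2 and compound 3 differ in two places at once, so their gap cannot be assigned. With nothing comparable on record, the expected step of a 1.6-fold higher number from compound 3 to compound 4 (0.20 log units; within the scatter) is small, not beyond the scatter. Compound 4 is therefore estimated at 16 nM, within a range of 4 nM to 63 nM.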

Compound 4, half-maximal inhibitory concentration: 39.8 nM
For compound 4 the middle estimate is 2.5-fold (0.40 log units) below the measured one; low and high end bracket the measured number.
By their numbers in this assay, from the lowest: compound 3; then compounds 2 and 4 (each within the scatter of the next); then compound 1.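

On an aromatic carbon between two ring nitrogen atoms, methyl in place of chloro gives a 4.0-fold higher number from compound 3 to compound 4 (0.60 log units; beyond the scatter) in this assay, the first single-place change read at this position of the core. The position is therefore not silent: exchanging one heavy atom for another, with no change in the hydrogen-bond donor or acceptor counts, moves the number beyond the scatter. No evidence on record bears on this step.

Open, going by these compounds, is how an amine or a methoxy group would read at this carbon. Also open, on these data alone, is whether this step holds with 3-chlorophenyl on the carbamate nitrogen.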